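This account rests on a few compounds, and the source may have more. Where it says the series, first, only, none or still open, it means among the compounds named here.

Compound 1 `CC(C)Oc1ccccc1OC(C)C1=NCCN1`, 0.7; compound 2 `CC(Oc1ccccc1OC1CC1)C1=NCCN1`, 0.7; compound 3 `C=C(C)c1ccccc1OC(C)C1=NCCN1`, 0.71.

In an assay on CHO cells with Alpha-2C adrenergic receptor (Homo sapiens) as the target (on this read-out lower numbers stand for smaller maximal responses and higher numbers for larger maximal responses), compound 1 stands level with compound 2, shown by no change at the digits printed from compound 1 to compound 2 (within the scatter), and compound 3 lies within the scatter of both, shown by a number 0.010 higher from compound 1 to compound 3 (within the scatter) and a number 0.010 higher from compound 2 to compound 3 (within the scatter). Compound 4 `CCc1ccccc1OC(C)C1=NCCN1` differs from compound 1 in one place: ethyl in place of isopropoxy on an aromatic carbon. Going by the values given here, two measured steps bear on this change. The step a number 0.010 higher from compound 1 to compound 3 (within the scatter) replaced the same isopropoxy group, and the step of no change at the digits printed from compound 1 to compound 2 (within the scatter) altered it; neither moved this assay beyond the scatter. Compound 4 is therefore expected to show a step of no change at the digits printed from compound 1 to compound 4 (within the scatter), none beyond the scatter. Compound 4 is estimated at 0.7, within 0.58 to 0.82.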

Compound 4, intrinsic activity: the largest response reached, as a fraction of the reference agonist's: 0.6
For compound 4 the middle estimate is 0.10 above the measured one, and the stated range covers the measured number.
By their numbers in this assay, from the lowest: compounds 4, 1, 2 and 3 (each within the scatter of the next, the first and the last beyond it).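

In this assay the step a number 0.11 lower from compound 3 to compound 4 (beyond the scatter) is the first among these compounds to pass the scatter, with ethyl in place of 1-methylethenyl on the same aromatic carbon. The steps a number 0.10 lower from compound 1 to compound 4 (within the scatter) and a number 0.10 lower from compound 2 to compound 4 (within the scatter) stay inside it, so ethyl stands apart from 1-methylethenyl but not from isopropoxy or cyclopropyloxy. Nothing shown gives a reason for this gap.

Going by these compounds, what a methyl, a propyl chain or an amine on this carbon would give stays open. So does whether the gap between ethyl and 1-methylethenyl holds in any other read-out.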